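A few compounds are considered here, and "the series" means these few. Any claim that something is new, unique, unknown or untested is made for them only; others in the source may bear on it.

Measured so far in a functional assay on a cell-free system (plasma) for inhibition of Thromboxane-A synthase (Homo sapiens); a higher number here means a weaker inhibitor, a lower number a stronger inhibitor:
compound 1 `COc1ccc(COCC(Cn2ccnc2)OCCCCC(=O)O)cc1`, 730 nM
compound 2 `CCOC(=O)CCCCCCOC(COCc1ccc(OC)cc1)Cn1ccnc1`, 4000 nM
compound 3 `COc1ccc(COCC(Cn2ccnc2)OCCCCCCC(C)(C)C(=O)O)cc1`, reported only as a limit, > 20000 nM

Compound 3 thus stands at the weak end of the three, with no number of its own, only the limit (the limit of > 20000 nM in this assay, at which 1 of the 3 values shown sits). Compound 4 `CCOC(=O)/C=C/CCCOC(COCc1ccc(OC)cc1)Cn1ccnc1` differs from it by 2-(ethoxycarbonyl)ethenyl in place of 4-carboxy-4-methylpentyl on a saturated chain carbon, three bonds along the chain from an oxygen on a saturated carbon. Among the compounds with values here, two measured steps bear on this change: an at least 5.0-fold higher number from compound 2 to compound 3 (0.69 log units; beyond the scatter), which runs the opposite way from ethyl ester to branched acid, and an at least 27-fold higher number from compound 1 to compound 3 (1.43 log units; beyond the scatter), which also leaves the branched acid as the weaker end. Reversing that change is therefore expected to give a lower number, by a modest to large step. Compound 4 is expected at 3000 nM in this assay, within 800 nM to 12000 nM. That expectation amounts to a step of an at least 6.6-fold lower number from compound 3 to compound 4 (0.82 log units; beyond the scatter).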

Compound 4, half-maximal inhibitory concentration: 10000 nM
Beside the measured number, compound 4's estimate is 3.3-fold (0.52 log units) below it; the measured number falls inside the stated range.
By their numbers in this assay, from the lowest: compound 1; then compound 2; then compound 4. At a limit, above all of these: compound 3.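

Among the ethyl esters, 2-(ethoxycarbonyl)ethenyl in place of 3-(ethoxycarbonyl)propyl raises the number, with a 2.5-fold higher number from compound 2 to compound 4 (0.40 log units; beyond the scatter). Against the unbranched acid the loss is larger, with a 14-fold higher number from compound 1 to compound 4 (1.14 log units; beyond the scatter). Against the branched acid the result gives only an at least 2.0-fold lower number from compound 3 to compound 4 (0.30 log units; that floor lies within the scatter), so the order of these two compounds is not secured, and compound 3 remains at a limit: the limit of > 20000 nM in this assay, at which 1 of the 4 values shown sits.

The compounds shown leave open how much of the rise from compound 2 comes from the double bond and how much from the chain length. They also leave open what a carboxylic acid in place of the ethyl ester would give on this unsaturated chain.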